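Swapping the aryl group on a thiosemicarbazone anticonvulsant

The compounds below may be only part of what the source reports. "The series", "measured", "known", "first", "only" and "open" are said of these compounds alone.

Compound 1 `S=C(N/N=C/c1ccccc1Cl)Nc1nc2ccc(Cl)cc2s1` gives 300 mg/kg in a functional assay on the whole organism with Mus musculus as the target, in the maximal electroshock model, with a stated time of 0.5 h; a higher number here means that more compound is needed for the effect, a lower number that less compound is needed.
Compound 2 `O=C(CNc1ccc(F)cc1)Nc1nc2ccc(Cl)cc2s1` gives 100 mg/kg in this assay.

Of the two measured compounds, compound 1 stands at the higher number, and the lower value of compound 2 lies beyond the usual scatter. Compound 3 `Oc1ccc(/C=N/NC(=S)Nc2nc3ccc(Cl)cc3s2)cc1` has not yet been measured. It differs from compound 1 in one place: 4-hydroxyphenyl in place of 2-chlorophenyl on a carbon with a double bond to nitrogen. For the measured compounds named here, no measured pair shows what this change does, so no step beyond the scatter is expected; the estimate for no change at the digits printed from compound 1 to compound 3 (within the scatter) is essentially flat. Compound 3 is therefore expected to give about 300 mg/kg in this assay, within a range from 100 mg/kg to 600 mg/kg.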

Compound 3, minimum effective dose: 100 mg/kg
The estimate for compound 3 lay 3.0-fold (0.48 log units) above the measured number; the range from low to high includes it.
By their numbers in this assay, from the lowest: compounds 2 and 3 (each within the scatter of the next); then compound 1.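

In this assay, the aryl group on the carbon with a double bond to nitrogen proves able to shift the number: 4-hydroxyphenyl in place of 2-chlorophenyl gives a 3.0-fold lower number from compound 1 to compound 3 (0.48 log units; beyond the scatter), a modest step. The earlier compounds shown here held no pair that tested this place. No measurement shown here explains the step.

On these data alone, it remains open whether the loss of the chlorine or the arrival of the hydroxyl carries the step. As far as these compounds go, how a plain phenyl or a 4-methoxyphenyl on the same carbon would read also remains open.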